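From 4-methoxyphenyl to 3,4-difluorophenyl

The source may hold more compounds than are shown below. What is called first, only, known or untested is meant among the compounds shown, and "the series" means these compounds.

Measured in a physicochemical assay for solubility, read by HPLC, in phosphate buffer, at pH 6.5; a higher number here means a more soluble compound, a lower number a less soluble compound:
Compound 1 `COC(=O)C1=C(C)NC(c2nccs2)=NC1(C)c1ccc(F)cc1`: 22 ug/mL
Compound 2 `COC(=O)C1=C(C)NC(c2nccs2)=NC1(C)c1ccc(F)cc1Cl`: 18 ug/mL
Compound 3 `COC(=O)C1=C(C)NC(c2nccs2)=NC1(C)c1ccc(OC)cc1`: 106 ug/mL

Compound 3 stands highest of the three in this assay, and both other compounds lie beyond the scatter from it. The next compound, compound 4 `COC(=O)C1=C(C)NC(c2nccs2)=NC1(C)c1ccc(F)c(F)c1`, has not yet been measured. It has 3,4-difluorophenyl in place of 4-methoxyphenyl on a saturated ring carbon.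

Among the measured compounds shown here, three measured steps bear on this change. The first is a 4.8-fold higher number from compound 1 to compound 3 (0.68 log units; beyond the scatter), where methoxy replaces fluoro on an aromatic carbon. The second is a 5.9-fold higher number from compound 2 to compound 3 (0.77 log units; beyond the scatter), where 4-methoxyphenyl replaces 2-chloro-4-fluorophenyl. Both are modest, and the change to compound 4 runs the opposite way, from methoxy to fluoro-bearing phenyl. The third is a 1.2-fold lower number from compound 1 to compound 2 (0.09 log units; within the scatter), which shows that adding chloro to the fluorophenyl group left the number within the scatter. For the measured compounds named here, no measured compound carries the 3,4-difluorophenyl group itself, so the expectation rests on compound 1 at 22 ug/mL and compound 2 at 18 ug/mL.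

A modest fall of similar size is therefore expected, an estimated 5.6-fold lower number from compound 3 to compound 4 (0.75 log units; beyond the scatter). The estimate for compound 4 is 19 ug/mL, with an expected range of 8 ug/mL to 42 ug/mL.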

Compound 4, solubility: 50 ug/mL
Estimate against measurement, compound 4: 2.6-fold (0.42 log units) below; measured number outside the range, above it.
By their numbers in this assay, from the lowest: compounds 2 and 1 (each within the scatter of the next); then compound 4; then compound 3.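

In this assay, the change gives a 2.1-fold lower number from compound 3 to compound 4 (0.33 log units; beyond the scatter) at this saturated ring carbon, so compound 3 stays highest, but a phenyl group bearing only fluoro can still stand clear of compounds 1 and 2. The extra halogen on the 4-fluorophenyl group is not neutral in every case: fluoro gives a 2.3-fold higher number from compound 1 to compound 4 (0.36 log units; beyond the scatter) in this series, whereas chloro gave a 1.2-fold lower number from compound 1 to compound 2 (0.09 log units; within the scatter) when the 2-chloro-4-fluorophenyl group was formed. The two halogen patterns also differ directly, with a 2.8-fold higher number from compound 2 to compound 4 (0.44 log units; beyond the scatter) on going to the 3,4-difluorophenyl group, and nothing shown here accounts for these differences.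

The compounds shown leave open whether the gain in compound 4 comes from the second fluoro itself or from where it sits on the phenyl ring, since the chloro and the added fluoro occupy different places. They also leave open how the number would move if the phenyl group carried both methoxy and fluoro, or an amine or a carboxylic acid in place of these groups.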